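Fluoro in place of methoxy on the shared urea core

A few compounds are considered here, and "the series" means these few. Any claim that something is new, unique, unknown or untested is made for them only; others in the source may bear on it.

Three ureas on a shared core have been run in an ADME assay on the whole organism with Oryza sativa as the target, tested at 1 uM; a lower number here means a stronger effect, a higher number a weaker effect of the compound at the concentration tested. Compound 1 `Cc1cccc(NC(=O)N[C@@H](C)c2ccccc2)c1` gives 100%. Compound 2 `C[C@H](NC(=O)Nc1cccc(C(F)(F)F)c1)c1ccccc1` gives 93%. Compound 3 `COc1cccc(NC(=O)N[C@@H](C)c2ccccc2)c1` gives 99%. Among these three numbers compound 3 stands second highest; its nearest neighbour is compound 1, with a step of a number 1 percentage points lower from compound 1 to compound 3 (within the scatter), while compound 2 lies furthest from it, with a step of a number 6 percentage points higher from compound 2 to compound 3 (within the scatter). The remaining pair gave a number 7 percentage points lower from compound 1 to compound 2 (within the scatter). None of the three steps reaches beyond the scatter of repeated runs.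

Compound 4 `C[C@H](NC(=O)Nc1cccc(F)c1)c1ccccc1` has not yet been measured in this assay. It differs from compound 3 in one place: fluoro in place of methoxy on an aromatic carbon. For the measured compounds named here, the steps that bear on this change are the three exchanges of one group on an aromatic carbon, methyl for methoxy, methyl for trifluoromethyl and trifluoromethyl for methoxy, each of which stayed within the scatter. On that ground no step beyond the scatter is expected for compound 4 in this assay, in either direction, and the expected step is a number 2 percentage points lower from compound 3 to compound 4 (within the scatter). For compound 4 the estimate is 97%, with a range from 88% to 102%.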

Compound 4, a percentage reported as activity, at one concentration (the size of the read-out at that concentration, not a potency): 94%
Estimate against measurement, compound 4: 3 percentage points above; measured number inside the range.
By their numbers in this assay, from the lowest: compounds 2, 4, 3 and 1 (each within the scatter of the next).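

At this place, on an aromatic carbon meta to a large group, fluoro now stands with methyl, methoxy and trifluoromethyl, and in this assay all three of its exchanges stay within the scatter: a number 5 percentage points lower from compound 3 to compound 4 (within the scatter), a number 1 percentage points higher from compound 2 to compound 4 (within the scatter), and a number 6 percentage points lower from compound 1 to compound 4 (within the scatter). The earlier compounds shown here held only exchanges among groups of 2 or more heavy atoms, whereas compound 4 carries fluoro, with 1 heavy atom and no hydrogen-bond acceptor, and still cannot be told apart from the other three, so no order among the four groups can be read from this read-out. Nothing given here bears on why these four groups read alike.

What remains open is whether any group at this place can produce a step beyond the scatter, since an amine, a carboxylic acid or a longer chain on this aromatic carbon is not among the compounds shown. Also open, on these data alone, is how the read-out responds to a change elsewhere on the shared core, which is the same in all four compounds.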